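Three Cyano Compounds and One Unmeasured Amine Change

This account rests on a few compounds, and the source may have more. Where it says the series, first, only, none or still open, it means among the compounds named here.

Compound 1 `COc1cc2c(Nc3ccc(C#N)cc3)ncnc2cc1OCCCN1CCC(C)CC1` - 16600 nM
Compound 2 `COc1cc2c(Nc3ccc(C#N)cc3)ncnc2cc1OCCCN1CCC(O)CC1` - 74900 nM
Compound 3 `COc1cc2c(Nc3ccc(C#N)cc3)ncnc2cc1OCCCN1CCc2ccccc2C1` - > 100000 nM (a limit)

These compounds share one core and differ only in the group at the end of the chain. In a functional assay on DU-145 cells (Homo sapiens) for antiproliferative activity, read by MTT assay, with a stated time of 72 h (on this read-out lower numbers stand for stronger inhibition and higher numbers for weaker inhibition), compound 3 is known only as a limit, > 100000 nM, and the limit of > 100000 nM in this assay, at which 1 of the 3 values shown sits, is the only such case here. Two steps lead to it: an at least 6.0-fold higher number from compound 1 to compound 3 (0.77 log units; beyond the scatter), and an at least 1.3-fold higher number from compound 2 to compound 3 (0.12 log units; that floor lies within the scatter), a floor that stays within the scatter.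

Compound 4 `COc1cc2c(Nc3ccc(C#N)cc3)ncnc2cc1OCCCN1CCC(N2CCCCC2)CC1` carries the change (4-(piperidin-1-yl)piperidin-1-yl in place of 1,2,3,4-tetrahydroisoquinolin-2-yl on a saturated chain carbon, three bonds along the chain from an oxygen on an aromatic ring). The entering group is a substituted piperidin-1-yl, like the 4-methylpiperidin-1-yl of compound 1 and the 4-hydroxypiperidin-1-yl of compound 2. Those two compounds are therefore the nearest guides, and the step of an at least 6.0-fold higher number from compound 1 to compound 3 (0.77 log units; beyond the scatter) suggests that leaving the 1,2,3,4-tetrahydroisoquinolin-2-yl group could bring a measurable number. The step of a 4.5-fold higher number from compound 1 to compound 2 (0.65 log units; beyond the scatter) shows, however, that the substituent on this ring matters, so the result remains uncertain.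

The expected step is an at least 3.1-fold lower number from compound 3 to compound 4 (0.49 log units; beyond the scatter), a modest one toward stronger inhibition. For compound 4 the estimated value is 32000 nM, with an expected range from 10000 nM to 100000 nM.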

Compound 4, half-maximal inhibitory concentration: 15600 nM
Compound 4: the middle estimate sits 2.1-fold (0.31 log units) above what was measured, within the range that was stated.
By their numbers in this assay, from the lowest: compounds 4 and 1 (each within the scatter of the next); then compound 2. At a limit, above all of these: compound 3.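

In this assay, moving from the fused ring system of the 1,2,3,4-tetrahydroisoquinolin-2-yl group to 4-(piperidin-1-yl)piperidin-1-yl at the end of the chain brings back a measurable number, with an at least 6.4-fold lower number from compound 3 to compound 4 (0.80 log units; beyond the scatter). Compound 3 is known only as a limit, so this step gives a floor and not a full size: the limit of > 100000 nM in this assay, at which 1 of the 4 values shown sits. On the saturated ring carbon, a whole second ring leaves the number where methyl has it, with a 1.1-fold lower number from compound 1 to compound 4 (0.03 log units; within the scatter), while piperidin-1-yl in place of hydroxy gives a 4.8-fold lower number from compound 2 to compound 4 (0.68 log units; beyond the scatter), so among these three substituents on the piperidine ring, hydroxy is the one that stands apart.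

The compounds shown leave open whether a primary amine or a carboxylic acid on that same ring carbon would give a number like that of compound 2 or like those of compound 1 and compound 4. They also leave open whether a morpholin-4-yl group or an open-chain dimethylamino group at the end of the chain, or a longer chain carrying 4-(piperidin-1-yl)piperidin-1-yl, would move the number at all.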